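Series notes: antiproliferative screen, third variant

The source may report more compounds than this note shows. Statements on the series, on what has been measured and on what is new or still open speak of the compounds shown alone.

Measured so far:
compound 1 `Cc1cc(O)c(C2=NN(c3ccc(S(N)(=O)=O)cc3)C(c3ccccc3O)C2)cc1Cl` — > 100000 nM
compound 2 `Cc1cc(O)c(C2=NN(c3ccc(S(N)(=O)=O)cc3)C(/C=C/c3ccccc3)C2)cc1Cl` — > 100000 nM

Compound 1 `Cc1cc(O)c(C2=NN(c3ccc(S(N)(=O)=O)cc3)C(c3ccccc3O)C2)cc1Cl` sits at the limit of a functional assay on K562 cells (Homo sapiens) for antiproliferative activity, with a stated time of 48 h; a higher number here means that more compound is tolerated, a lower number that less compound is tolerated; its value of > 100000 nM is a limit, not a number. Compound 2 `Cc1cc(O)c(C2=NN(c3ccc(S(N)(=O)=O)cc3)C(/C=C/c3ccccc3)C2)cc1Cl` likewise gives only a limit in this assay, > 100000 nM. The step that the two limits leave unreadable from compound 1 to compound 2 is therefore unreadable. Compound 2 stands where every value in the set stands, at the common limit (the limit of > 100000 nM in this assay, at which 2 of the 2 values shown sit).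

Compound 3 `COc1ccc(C2CC(c3cc(Cl)c(C)cc3O)=NN2c2ccc(S(N)(=O)=O)cc2)cc1OC` carries 3,4-dimethoxyphenyl in place of 2-phenylethenyl on a saturated ring carbon. Among the compounds with values here, no measured step bears on this change: the single step available is hidden by the two limits, and there is no readable number in the set from which a direction could be taken. The expectation is that the change does not lift the series off the limit, so a step of none beyond the scatter is expected, a number no higher from compound 2 to compound 3 (the limit leaves the size open), with compound 3 most likely reported as a limit again. Compound 3 is estimated at 100000 nM, in a range from 30000 nM to 300000 nM.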

Compound 3, concentration lethal to 50% of the cells: > 100000 nM
Compound 3: no number, only a limit; the forecaster's own chance of this, stated with the estimate: 70%; the middle value sits exactly at the limit.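

In this assay compound 3 gives > 100000 nM, a limit and not a number. The steps to compound 3 from compound 1 and from compound 2 cannot be read, as all the values sit at one limit: the limit of > 100000 nM in this assay, at which 3 of the 3 values shown sit.

The compounds shown leave open whether any group on the saturated ring carbon gives a readable number in this assay.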